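Allyloxy to cyclopropylmethoxy on the acid and its ethyl ester

The compounds below may be only part of what the source reports. "The series", "measured", "known", "first", "only" and "open" are said of these compounds alone.

Of the compounds shown here, three have been measured in a functional assay on the whole organism (strain Sprague-Dawley) for inhibition, with Rattus norvegicus as the target, with a stated time of 10 min; on this read-out lower numbers stand for an effect already at smaller amounts and higher numbers for an effect only at larger amounts of compound. Compound 1 `C=CCOc1ccccc1-c1ncc(C(=O)O)c(=O)[nH]1` gives 0.5 mg/kg. Compound 2 `O=C(O)c1cnc(-c2ccccc2OCC2CC2)[nH]c1=O` gives 0.1 mg/kg. Compound 3 `C=CCOc1ccccc1-c1ncc(C(=O)OCC)c(=O)[nH]1` gives 0.5 mg/kg. Compound 4 `CCOC(=O)c1cnc(-c2ccccc2OCC2CC2)[nH]c1=O` is not yet measured.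

The change from compound 1 to compound 2 is cyclopropyl in place of vinyl on a saturated chain carbon bound to an oxygen on an aromatic ring; in this assay it gave a 5.0-fold lower number from compound 1 to compound 2 (0.70 log units; beyond the scatter). The change from compound 1 to compound 3 is ethyl in place of hydrogen on an oxygen next to a carbonyl group; in this assay it gave no change at the digits printed from compound 1 to compound 3 (within the scatter), so the acid and its ethyl ester stand level at the digits printed, together the highest numbers of the three.

Compound 3 and compound 4 differ by cyclopropyl in place of vinyl on a saturated chain carbon bound to an oxygen on an aromatic ring, which is the same change as that from compound 1 to compound 2, made on the same place on the ethyl ester core instead of the acid core. Among the compounds with values here, only a single measured example of this change exists, so how far it carries over from one core to the other is unknown; the acid and the ester, however, give the same number, which gives no sign that the ester core behaves differently.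

Within the data shown here, for compound 4 the step from compound 3 is expected to be a 5.0-fold lower number from compound 3 to compound 4 (0.70 log units; beyond the scatter), because a 5.0-fold lower number from compound 1 to compound 2 (0.70 log units; beyond the scatter) and that is the only measured instance of this change. Compound 4 is therefore estimated at 0.1 mg/kg in this assay, with a range of 0.04 mg/kg to 0.3 mg/kg to allow for the scatter of a single transferred step.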

Compound 4, dose for 50% inhibition: 0.3 mg/kg
Compound 4: middle estimate off by 3.0-fold (0.48 log units), on the low side; the measured number falls inside the stated range.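

In this assay, allyloxy to cyclopropylmethoxy on the ethyl ester core gives a 1.7-fold lower number from compound 3 to compound 4 (0.22 log units; within the scatter), so the step seen on the acid core is not matched in size: the same change on two cores in this assay, a 5.0-fold lower number (0.70 log units; beyond the scatter) from compound 1 to compound 2 and a 1.7-fold lower number (0.22 log units; within the scatter) from compound 3 to compound 4, 3.0-fold (0.48 log units) apart, beyond the scatter of two such steps. Read the other way round, ethyl in place of hydrogen on the cyclopropylmethoxy compounds gives a 3.0-fold higher number from compound 2 to compound 4 (0.48 log units; beyond the scatter), while the same change on the allyloxy compounds left the printed number in place, so the two changes do not simply add up: the same change on two cores in this assay, no change at the digits printed (within the scatter) from compound 1 to compound 3 and a 3.0-fold higher number (0.48 log units; beyond the scatter) from compound 2 to compound 4, 3.0-fold (0.48 log units) apart, beyond the scatter of two such steps. This shows that, within these four compounds, the size of the step depends on the core it is made on, so a step from the acid core cannot be transferred at full size to the ethyl ester core; it does not show why the steps differ, nor whether the same holds for any other pair of cores in the series.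

The compounds shown leave open whether the gap between the two steps persists with other groups on the ether oxygen, such as a longer chain or benzyl, or with other replacements of the acid, such as a methyl ester or an amide. On these data alone, how these four compounds would compare at a stated time other than the one used here also remains open.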